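Same Atoms, Joined Differently: From Compound 2 to Compound 3

This account rests on a few compounds, and the source may have more. Where it says the series, first, only, none or still open, it means among the compounds named here.

In a functional assay, with a stated time of 30 min (on this read-out lower numbers stand for an effect already at smaller amounts and higher numbers for an effect only at larger amounts of compound), compound 1 (`CC(C)=NNc1nc(-c2cccc([N+](=O)[O-])c2)cs1`) gives 510000 nM and compound 2 (`CCCC/C(C)=N\Nc1nc(-c2cccc([N+](=O)[O-])c2)cs1`) gives 520000 nM. Among the compounds with values here, these two values lie within the scatter of each other, so compound 2 cannot be separated from compound 1, the only other compound measured. Compound 3 (`CCC/C(CC)=N\Nc1nc(-c2cccc([N+](=O)[O-])c2)cs1`) has yet to be measured in this assay. Its difference from compound 2 is a group of 7 heavy atoms (6 carbon, 1 nitrogen; no ring) in place of a group of 7 heavy atoms (6 carbon, 1 nitrogen; no ring), on a nitrogen on an aromatic ring; the two have the same atoms, joined differently. Within the data shown here, one measured step bears on this: a 1.0-fold higher number from compound 1 to compound 2 (0.01 log units; within the scatter), where propyl in place of hydrogen on a saturated chain carbon stayed within the scatter. That step added atoms, whereas this change adds none. No step beyond the scatter is therefore expected, and the estimated change is a 1.0-fold lower number from compound 2 to compound 3 (0.02 log units; within the scatter). For compound 3 the expected value is 500000 nM, with an estimated range from 280000 nM to 900000 nM.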

Compound 3, half-maximal effective concentration: 530000 nM
For compound 3 the middle estimate is 1.1-fold (0.03 log units) below the measured one; the measured number falls inside the stated range.
By their numbers in this assay, from the lowest: compounds 1, 2 and 3 (each within the scatter of the next).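

In this assay, the swap of one group of 7 heavy atoms for another with the same atoms joined differently, on a nitrogen on an aromatic ring, gives a 1.0-fold higher number from compound 2 to compound 3 (0.01 log units; within the scatter) and so shows that rearranging the chain carbons at this place does not separate the two compounds. The larger exchange at this place gives a 1.0-fold higher number from compound 1 to compound 3 (0.02 log units; within the scatter) and also stays within the scatter, so across these three compounds neither the size of this group nor the way its atoms are joined moves the read-out beyond it. No measured evidence is available to explain this result.

As far as these compounds go, what a phenyl ring, an amine or a much longer chain would do at this place remains open. So does the effect of replacing the nitro group on the shared core with a carboxylic acid or an amine.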